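The source may report more compounds than this note shows. Statements on the series, on what has been measured and on what is new or still open speak of the compounds shown alone.

Measured so far:

Compound 1, `CC(C)(C)N(NC(=O)c1ccccc1)C(=O)c1ccccc1C(F)(F)F`: 631 nM
Compound 2, `Cc1ccccc1C(=O)N(NC(=O)c1ccccc1)C(C)(C)C`: 224 nM
Compound 3, `CC(C)c1ccc(C(=O)NN(C(=O)c2ccccc2Cl)C(C)(C)C)cc1`: 24.6 nM

These three compounds share a core with two carbonyl groups joined through a hydrazide unit, and they were tested in an assay on cells for agonist activity at ecdysone receptor (Bombyx mori), read by a luciferase reporter, with a stated time of 24 h; a lower number here means that less compound is needed, a higher number that more compound is needed for the effect. Compound 2 gives 224 nM, the second highest of the three numbers; its nearest neighbour is compound 1 with 631 nM, and compound 3 stands furthest away with 24.6 nM. Among the compounds with values here, the one step between compounds that differ in a single place is a 2.8-fold lower number from compound 1 to compound 2 (0.45 log units; beyond the scatter), a swap of one small group on the aromatic ring.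

Compound 4, `CC(C)(C)N(NC(=O)c1ccccc1)C(=O)C1CCCCC1`, has not yet been measured. It differs from compound 2 by cyclohexyl in place of 2-methylphenyl on a carbonyl carbon. Within the data shown here, no measured step touches this change: the step from compound 1 to compound 2 only exchanged a group on that aromatic ring, whereas here the whole ring is replaced by a non-aromatic one. Among the measured compounds shown here, with no direct precedent, the expectation rests on the size of the change alone; a modest rise in the number, a 3.6-fold higher number from compound 2 to compound 4 (0.55 log units; beyond the scatter), is expected, with wide uncertainty in both directions. The estimate for compound 4 in this assay is 800 nM, expected to fall between 150 nM and 4500 nM.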

Compound 4, half-maximal effective concentration: 46800 nM
Compound 4: middle estimate off by 59-fold (1.77 log units), on the low side; the whole stated range lies below it.
By their numbers in this assay, from the lowest: compound 3; then compound 2; then compound 1; then compound 4.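

In this assay, putting cyclohexyl in place of 2-methylphenyl on this carbonyl carbon gives a 210-fold higher number from compound 2 to compound 4 (2.32 log units; beyond the scatter), far larger than the change made within the aromatic ring, a 2.8-fold lower number from compound 1 to compound 2 (0.45 log units; beyond the scatter). Compounds 1 and 2 showed only that this position responds to a small group on the ring; compound 4 shows that replacing an aromatic ring with a non-aromatic one of similar size, with no hydrogen-bond donors or acceptors on either, can cost far more. Nothing available explains why the step is so large.

Still open, from the compounds shown here alone, is how a pyridine ring or an unsubstituted phenyl ring would behave at this carbonyl carbon. Also open, going by these compounds, is whether the same swap would have a similar size in the setting of compound 3, which carries an isopropyl group and a chlorine.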